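Lengthening the ester chain: growth inhibition notes

The compounds below may be only part of what the source reports. "The series", "measured", "known", "first", "only" and "open" are said of these compounds alone.

compound 1 `C=C[C@@](C)(/C=C/c1ccc(OC(=O)CC)cc1)CCC=C(C)C`: 48%
compound 2 `C=C[C@@](C)(/C=C/c1ccc(OC(=O)CCCC)cc1)CCC=C(C)C`: 23%

In a functional assay on HeLa cells (Homo sapiens) for inhibition, with a stated time of 48 h, tested at 50 uM (on this read-out higher numbers stand for more inhibition of growth at the one concentration tested and lower numbers for less inhibition of growth), compound 2 stands lowest of the two measured compounds, at 23%. Compound 3 `C=C[C@@](C)(/C=C/c1ccc(OC(=O)CCCCC)cc1)CCC=C(C)C` differs from it by one change: methyl in place of hydrogen on a saturated chain carbon, four bonds along the chain from a carbonyl carbon. Among the compounds with values here, one measured step bears on this: a number 25 percentage points lower from compound 1 to compound 2 (beyond the scatter), where ethyl entered on the same chain. Here only methyl enters, so a smaller fall in the same direction is expected. The expected step is a number 9 percentage points lower from compound 2 to compound 3 (within the scatter). Compound 3 is estimated at 14%, within a range of 2% to 28%.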

Compound 3, percent growth inhibition at one concentration: 50%
The estimate for compound 3 lay 36 percentage points below the measured number; the whole stated range lies below it.
By their numbers in this assay, from the lowest: compound 2; then compounds 1 and 3 (each within the scatter of the next).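

In this assay methyl at this place gives a number 27 percentage points higher from compound 2 to compound 3 (beyond the scatter) and so undoes the earlier fall. The full lengthening of the chain gives only a number 2 percentage points higher from compound 1 to compound 3 (within the scatter) and so no steady fall with chain length holds across these esters, with compound 2 alone standing apart from the other two. Nothing available explains this dip and recovery.

Still open, on these data alone, is whether a longer chain holds the number near that of compound 3 or lowers it again. Also open, as far as these compounds go, is whether an amine or a carboxylic acid at the chain end would fit the same pattern.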